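A few compounds are considered here, and "the series" means these few. Any claim that something is new, unique, unknown or untested is made for them only; others in the source may bear on it.

Compound 3, whose structure is `Cc1ccc(C2CNN=C2S(=O)(=O)CC2=NCCO2)cc1`, was tested in a functional assay, read by Griess assay, with a stated time of 150 min, tested at 75 ug/mL (a higher number here means a stronger effect of the compound at the concentration tested, a lower number a weaker effect), and gave 49.7%. Its nearest companion is compound 1, `O=S(=O)(CC1=NCCO1)c1n[nH]cc1-c1ccccc1`, which in this assay gave 54.7%, a gap within the scatter, so the two numbers stand together rather than in any order. Compound 2, `O=S(=O)(CC1=NCCO1)C1=NNCC1c1ccccc1`, shares the core of compound 3 but bears a plain phenyl group; in this assay compound 2 was reported as "not active" (no number reported), without a number. Compound 4, `O=S(=O)(CC1=NCCO1)C1=NNCC1c1ccc(Cl)cc1`, is the next member to be measured in this assay. Relative to compound 3 the change is chloro in place of methyl on an aromatic carbon. Among the compounds with values here, no step between two measured compounds has been recorded for this kind of change, so no size can be read from the series itself. Compound 4 is expected to stay near compound 3, the step of a number 4.7 percentage points lower from compound 3 to compound 4 (within the scatter) estimated to lie within the scatter, with a downward lean because compound 2 at "not active" (no number reported) shows that the substituted aryl group is not to be taken for granted. For compound 4 the estimate in this assay is 45%, within 20% to 65%.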

Compound 4, a percentage reported as activity, at one concentration (the size of the read-out at that concentration, not a potency): "not active" (no number reported)
For compound 4 the study gives words and no number, and the estimate cannot be compared.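

In this assay, within the data shown here, compound 4 gives "not active" (no number reported) and so no step from compound 3 can be read from it. No measurement shown bears on this result. The compounds shown leave open how large the change from 4-methylphenyl to 4-chlorophenyl is in numbers.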